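Adding a Second Methoxy Group to an Aryl Hydrazone

The source may hold more compounds than are shown below. What is called first, only, known or untested is meant among the compounds shown, and "the series" means these compounds.

Measured so far in a functional assay on the whole organism (strain Wistar) for inhibition, with Rattus norvegicus as the target, read by paw edema, with a stated time of 30 min, at a dose of 10 mg/kg by the intraperitoneal route; a lower number here means less inhibition, a higher number more inhibition at the dose given (going by the name of the read-out):
- compound 1, `O=C(N/N=C/c1ccc(O)c(O)c1)c1cccnc1Nc1cccc(C(F)(F)F)c1`: 51.4%
- compound 2, `COc1cccc(/C=N/NC(=O)c2cccnc2Nc2cccc(C(F)(F)F)c2)c1`: 52.8%

Going by the values given here, compound 2 nominally stands at the top of these two numbers, yet the only measured step, a number 1.4 percentage points higher from compound 1 to compound 2 (within the scatter), lies within the scatter, so compound 1 and compound 2 cannot be told apart on this assay. That step swapped 3-methoxyphenyl for 3,4-dihydroxyphenyl on the carbon with a double bond to nitrogen and changed nothing beyond the scatter.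

Compound 3, `COc1ccc(/C=N/NC(=O)c2cccnc2Nc2cccc(C(F)(F)F)c2)cc1OC`, is not yet measured. It differs from compound 2 by methoxy in place of hydrogen on an aromatic carbon. Among the compounds with values here, the one step that bears on it, from compound 1 to compound 2, touched the same ring and stayed within the scatter, so no step beyond the scatter is expected here either. Compound 3 is therefore estimated at 52% in this assay, with a range from 40% to 64%. The step this estimate implies is a number 0.8 percentage points lower from compound 2 to compound 3 (within the scatter), expected to be within the scatter.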

Compound 3, a percentage reported as inhibition, in the whole organism at one dose (the size of the read-out at that dose, not a potency): 60.1%
Beside the measured number, compound 3's estimate is 8.1 percentage points below it; low and high end bracket the measured number.
By their numbers in this assay, from the lowest: compounds 1, 2 and 3 (each within the scatter of the next).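

In this assay, methoxy in place of hydrogen on the aromatic carbon ortho to a methoxy group gives a number 7.3 percentage points higher from compound 2 to compound 3 (within the scatter), so this position takes a second methoxy without a shift that can be told from the scatter. The 3,4-dimethoxyphenyl and the 3,4-dihydroxyphenyl on the carbon with a double bond to nitrogen also cannot be told apart, with a number 8.7 percentage points higher from compound 1 to compound 3 (within the scatter), and so compound 1, compound 2 and compound 3 all remain within the scatter of one another. No measurement at hand bears on why these numbers fall as they do.

As far as these compounds go, whether any change at this position can move the read-out beyond the scatter stays open, for example an amine, a carboxylic acid or a longer alkoxy chain in place of the new methoxy. The compounds shown also leave open how the shared core responds when the trifluoromethyl group is replaced by a chlorine atom.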